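Pyrrolidin-1-yl for dimethylamino on the side chain

The source may report more compounds than this note shows. Statements on the series, on what has been measured and on what is new or still open speak of the compounds shown alone.

Values in an in vitro ADME assay on microsomes from liver (Homo sapiens) for metabolic stability, read by LC-MS (a higher number here means that the compound lasts longer, a lower number that the compound disappears faster), are as follows.
- Compound 1 `CC(C)N1C(=O)C(=O)N=C1/N=C(\NCc1ccccc1)Nc1ccc(Cl)c(Cl)c1` gives > 1 h as a limit.
- Compound 2 `CC(C)N1C(=O)C(=O)N=C1/N=C(\NCCN(C)C)Nc1ccc(Cl)c(Cl)c1` gives > 1 h as a limit.

In this assay compound 2 stands at > 1 h and this is a limit, not a number. Going by the values given here, the series so far amounts to the limit of > 1 h in this assay, at which 2 of the 2 values shown sit, and offers no measured half-life. Compound 3 `CC(C)N1C(=O)C(=O)N=C1/N=C(\NCCN1CCCC1)Nc1ccc(Cl)c(Cl)c1` carries pyrrolidin-1-yl in place of dimethylamino on a saturated chain carbon, two bonds along the chain from an amine nitrogen. Among the compounds with values here, the one measured step that bears on this is a step that the two limits leave unreadable from compound 1 to compound 2 and it gives no size to carry over. No change beyond the scatter is therefore expected in this assay, in either direction. The expected step is a step that the limit leaves unreadable from compound 2 to compound 3 and it is only a working figure. For compound 3 the estimated half-life is 1.5 h (range 1 h to 4 h). A further limit is the likeliest report for compound 3.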

Compound 3, half-life: 0.886 h
The estimate for compound 3 lay 1.7-fold (0.23 log units) above the measured number, and the stated range ends above it.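

In this assay, compound 3 gives the first measured half-life in the series, 0.886 h, with pyrrolidin-1-yl in place of dimethylamino. The change from dimethylamino reads as an at least 1.1-fold lower number from compound 2 to compound 3 (0.05 log units; that floor lies within the scatter), and the change from phenyl to (pyrrolidin-1-yl)methyl reads as an at least 1.1-fold lower number from compound 1 to compound 3 (0.05 log units; that floor lies within the scatter); both are floors only, so neither establishes a real loss of stability. The step from compound 1 to compound 2 stays unreadable, as the other two compounds rest on one limit: the limit of > 1 h in this assay, at which 2 of the 3 values shown sit.

From the compounds shown here alone, how far the true half-lives of compound 1 and compound 2 lie above that of compound 3 remains open. Also open, going by these compounds, is whether a piperidin-1-yl or morpholin-4-yl group, or a longer chain carrying pyrrolidin-1-yl, would give a number or a limit in this assay.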